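The source may hold more compounds than are shown below. What is called first, only, known or untested is meant among the compounds shown, and "the series" means these compounds.

Measured so far:
- compound 1 `Cc1ccc(-c2ccc(CO[C@H]3C[C@@H](N=C=S)C3)cc2)cc1`: 26 nM
- compound 2 `COc1ccc(-c2cnc(C(=O)N[C@H]3C[C@@H](N=C=S)C3)cn2)cc1`: 853 nM

In an assay on isolated protein for inhibition of N-acylethanolamine-hydrolyzing acid amidase (Homo sapiens), read by fluorescence, with a stated time of 90 min (a lower number here means a stronger inhibitor, a higher number a weaker inhibitor), compound 1 gives 26 nM and compound 2 gives 853 nM, so compound 1 holds the lower of the two numbers, with compound 2 well beyond the scatter from it. Compound 3 `Cc1ccc(-c2ccc(CO[C@H]3C[C@H](N=C=S)C3)cc2)cc1` keeps every atom and bond of compound 1; the change is the two compounds have the same atoms and bonds; at least one stereo element is drawn with a configuration in one of them and without one in the other: 2 of 3 stereo elements differ; a stereocentre at a saturated ring carbon is drawn s in compound 1 and r in compound 3; a stereocentre at a saturated ring carbon is drawn s in compound 1 and r in compound 3, so the two ring stereocentres of compound 1 are drawn with the opposite configuration in compound 3. Among the measured compounds shown here, no pair of measured compounds in this set differs only in ring stereochemistry, so the size of this step in this assay cannot be read from the data. A diastereomer of a potent inhibitor is expected to lose some potency, and a step from compound 1 to compound 3 of a 5.8-fold higher number from compound 1 to compound 3 (0.76 log units; beyond the scatter) is estimated. For compound 3 the expected value in this assay is 150 nM, within 30 nM to 800 nM.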

Compound 3, half-maximal inhibitory concentration: 580 nM
Beside the measured number, compound 3's estimate is 3.9-fold (0.59 log units) below it; low and high end bracket the measured number.
By their numbers in this assay, from the lowest: compound 1; then compounds 3 and 2 (each within the scatter of the next).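

In this assay, compounds 1 and 2 differ in more than one place, so they could not isolate the ring stereocentres, whereas compounds 1 and 3 keep the same atoms and bonds and give a 22-fold higher number from compound 1 to compound 3 (1.35 log units; beyond the scatter). The drawn configuration at these two saturated ring carbons is thus enough by itself to produce a large shift in this assay, with no substituent changed. This reading rests on how the two compounds are drawn: the fact that one of compounds 1 and 3 is drawn with a defined configuration and the other without, at the place where they differ

The compounds shown leave open whether the amide-linked compound 2 would respond in the same way to the same inversion of its ring stereocentres. They also leave open whether the isothiocyanate could be replaced at this ring carbon by a nitrile or a carboxylic acid under either configuration.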